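The source may hold more compounds than are shown below. What is called first, only, known or untested is meant among the compounds shown, and "the series" means these compounds.

The measured compounds:
Compound 1, `CC(=O)N[C@@H]1CCCc2c1cncc2N1C(=O)c2ccc(Cl)cc2[C@@H]1C`, gives 4 nM in an assay on cells for inhibition of cytochrome P450 11B2, mitochondrial (Homo sapiens), read by HTRF; on this read-out higher numbers stand for weaker inhibition and lower numbers for stronger inhibition.
Compound 2, `Cc1cccnc1C(=O)NCc1cncc(N2C(=O)c3ccc(Cl)cc3C2(C)C)c1`, gives 9 nM in this assay.
Compound 3, `O=C(Nc1cccnc1)c1ccc(Cl)cc1F`, gives 297 nM in this assay.

Among these three numbers compound 2 stands second highest. Its nearest neighbour is compound 1, whose number is lower by a margin beyond the usual scatter of repeated measurements; compound 3 lies furthest away, with a much higher number, again well beyond the scatter.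

Compound 4, `CC1(C)c2cc(Cl)ccc2C(=O)N1c1cncc(CNS(C)(=O)=O)c1`, has not yet been measured in this assay. It keeps the shared core of compound 2 and differs in one place: methylsulfonyl in place of (3-methylpyridin-2-yl)carbonyl on an amine nitrogen. For the measured compounds named here, no step between two measured compounds mirrors this exchange, so nothing measured shows directly what it does. The closest guide is compound 1, which carries another group on the nitrogen of the corresponding chain and gives 4 nM, which suggests that this part of the molecule accepts more than one group while the inhibition stays strong. Compound 4 is therefore expected to land near compound 2, and the expected step is a 1.7-fold higher number from compound 2 to compound 4 (0.22 log units; within the scatter), toward somewhat weaker inhibition but not far beyond the scatter. Compound 4 is estimated at 15 nM, with a range from 4 nM to 60 nM.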

Compound 4, half-maximal inhibitory concentration: 33 nM
Beside the measured number, compound 4's estimate is 2.2-fold (0.34 log units) below it; the measured number falls inside the stated range.
By their numbers in this assay, from the lowest: compound 1; then compound 2; then compound 4; then compound 3.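

In this assay the exchange of (3-methylpyridin-2-yl)carbonyl for methylsulfonyl on the amine nitrogen gives a 3.7-fold higher number from compound 2 to compound 4 (0.56 log units; beyond the scatter), a modest step toward weaker inhibition that lies beyond the usual scatter. For the compounds shown here, this is the first direct reading of a change at this position, and it shows that the position is not indifferent to the group it carries, although a much smaller group without a ring, with the same counts of hydrogen-bond donors and acceptors, costs only a modest part of the inhibition. Nothing at hand explains the size of this step.

Because the ring and the carbonyl leave together, the compounds shown do not separate the part played by the ring from that of the change from carbonyl to sulfonyl, a question that a plain acetyl group or a benzenesulfonyl group on the same nitrogen would address. They also leave open how this assay would read a bare amine at this place or a longer chain on the sulfonyl, such as ethylsulfonyl.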